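Urea nitrogen substituent: butyl cut down to methyl

A few compounds are considered here, and "the series" means these few. Any claim that something is new, unique, unknown or untested is made for them only; others in the source may bear on it.

Measured so far, in an assay on isolated protein for inhibition of histamine H2 receptor (Cavia porcellus); on this read-out lower numbers stand for tighter binding and higher numbers for weaker binding:
compound 1 `O=C(NCCCOc1cccc(CN2CCCCC2)c1)Nc1ccccc1`: 126 nM
compound 2 `O=C(NCCCOc1cccc(CN2CCCCC2)c1)Nc1ccc(C(F)(F)F)cc1`: 1700 nM
compound 3 `CCCCNC(=O)NCCCOc1cccc(CN2CCCCC2)c1`: 81.3 nM

Compound 3 gives the lowest number of the three, but its nearest neighbour is compound 1, and a 1.5-fold lower number from compound 1 to compound 3 (0.19 log units; within the scatter) is within the scatter, so these two cannot be ordered against each other; only compound 2 stands clearly apart, by a 21-fold lower number from compound 2 to compound 3 (1.32 log units; beyond the scatter). Compound 4 `CNC(=O)NCCCOc1cccc(CN2CCCCC2)c1` has not been measured. It differs from compound 3 by hydrogen in place of propyl on a saturated chain carbon bound to an amide-type nitrogen, so the urea keeps its two nitrogen hydrogens and loses only chain length. For the measured compounds named here, no measured step shortens or lengthens a chain on the urea nitrogen. The steps on hand concern the aryl side: a 13-fold higher number from compound 1 to compound 2 (1.13 log units; beyond the scatter) was large, whereas the exchange of phenyl for butyl, a 1.5-fold lower number from compound 1 to compound 3 (0.19 log units; within the scatter), was not. Nothing here says how much of the butyl chain matters, so the expectation for this assay is a step of at most modest size, with a wide range in either direction. Compound 4 is therefore estimated at 150 nM, with a range from 40 nM to 600 nM. The expected step of a 1.8-fold higher number from compound 3 to compound 4 (0.27 log units; within the scatter) leans toward a somewhat higher number but remains close to the scatter.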

Compound 4, dissociation constant: 155 nM
For compound 4 the middle estimate is 1.0-fold (0.01 log units) below the measured one; the range from low to high includes it.
By their numbers in this assay, from the lowest: compounds 3, 1 and 4 (each within the scatter of the next); then compound 2.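

In this assay, for the compounds shown here, butyl cut down to methyl on the urea nitrogen gives a 1.9-fold higher number from compound 3 to compound 4 (0.28 log units; within the scatter), the first reading of chain length at this position: within the scatter, so the loss of propyl from the chain leaves no change that can be told apart here. Methyl also cannot be separated from phenyl on this nitrogen, with a 1.2-fold higher number from compound 1 to compound 4 (0.09 log units; within the scatter), so butyl, methyl and phenyl all sit within the scatter of their neighbours in the ordered series, and the only substituent that stands apart among these compounds is 4-(trifluoromethyl)phenyl, with an 11-fold lower number from compound 2 to compound 4 (1.04 log units; beyond the scatter). No supporting data are available on why this position accepts such different groups.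

Open, as far as these compounds go, is whether the urea nitrogen keeps this behaviour with a longer chain such as octyl, or with a chain ending in an amine or a carboxylic acid. Also open, from the compounds shown here alone, is whether the large step seen with 4-(trifluoromethyl)phenyl is particular to trifluoromethyl or would recur with another group on the phenyl, such as methoxy or chlorine.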